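Dichloro to monochloro purine core: removing one chloro

The source may report more compounds than this note shows. Statements on the series, on what has been measured and on what is new or still open speak of the compounds shown alone.

Two compounds of this series have numbers in a functional assay on Hs-578T cells (Homo sapiens) for cytotoxicity, read by sulforhodamine B assay, with a stated time of 48 h; on this read-out higher numbers stand for weaker inhibition of growth and lower numbers for stronger inhibition of growth. Compound 1 `ClCc1ccc(Cn2cnc3c(Cl)ncnc32)cc1` gives 10200 nM. Compound 2 `ClCc1ccccc1Cn1cnc2c(Cl)nc(Cl)nc21` gives 1170 nM, the lowest of the two numbers; its nearest neighbour is compound 1, whose number is higher by a margin beyond the scatter. Within the data shown here, compound 1 and compound 2 differ in two places, so no single step connects them.

Compound 3 `ClCc1ccccc1Cn1cnc2c(Cl)ncnc21` has not been measured. It differs from compound 2 in one place: hydrogen in place of chloro on an aromatic carbon. Among the measured compounds shown here, no measured pair shows this change alone. For the measured compounds named here, compound 3 is expected to give a higher number than compound 2, by a 3.4-fold higher number from compound 2 to compound 3 (0.53 log units; beyond the scatter), because compound 1, the only other compound with hydrogen at that carbon, gives 10200 nM. The estimate for compound 3 in this assay is 4000 nM, with a range from 1200 nM to 15000 nM.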

Compound 3, concentration for 50% growth inhibition: 2290 nM
Estimate against measurement, compound 3: 1.7-fold (0.24 log units) above; measured number inside the range.
By their numbers in this assay, from the lowest: compounds 2 and 3 (each within the scatter of the next); then compound 1.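

Among these compounds, the first measured pair with this change alone is in this assay, where hydrogen in place of chloro on the aromatic carbon between two ring nitrogen atoms gives a 2.0-fold higher number from compound 2 to compound 3 (0.29 log units; within the scatter) and so leaves the two compounds within the scatter of each other. On this read-out, the chloro group at this carbon is therefore not required for the growth inhibition seen with compound 2, since compound 3 cannot be told apart from it. Nothing among the data shown explains why this swap of one chlorine atom for hydrogen leaves the number within the scatter.

Still open, from the compounds shown here alone, is whether a larger group at this carbon, such as an amine, a methoxy group or a morpholine ring, would shift the number beyond the scatter. Also open, going by these compounds, is whether hydrogen in place of chloro gives a similar step when the chloromethyl group sits as it does in compound 1.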